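The source may report more compounds than this note shows. Statements on the series, on what has been measured and on what is new or still open speak of the compounds shown alone.

Working notes on the series.

Compound 2 `OC[C@H]1O[C@@H](n2cnc3c(NCc4cccc(Br)c4)ncnc32)[C@H](O)[C@@H]1O` is the starting point. In a functional assay on B16 cells (Mus musculus) for antiproliferative activity, with a stated time of 72 h (a lower number here means a stronger inhibitor, a higher number a weaker inhibitor), compound 2 gives only a limit, > 166000 nM. Compound 1 `OC[C@H]1O[C@@H](n2cnc3c(NCc4ccccc4F)ncnc32)[C@H](O)[C@@H]1O` likewise gives only a limit in this assay, > 166000 nM. Compound 3 `COc1ccc(CNc2ncnc3c2ncn3[C@@H]2O[C@H](CO)[C@@H](O)[C@H]2O)c(OC)c1` has no result in this assay, "not determined" (no result reported). Among the compounds with values here, the one measured step, from compound 1 to compound 2 in this assay, is a step that the two limits leave unreadable from compound 1 to compound 2, so it carries no readable size; both ends sit at the limit of > 166000 nM in this assay, at which 2 of the 3 values shown sit.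

The step to compound 4 `OC[C@H]1O[C@@H](n2cnc3c(NCc4c(F)ccc(F)c4F)ncnc32)[C@H](O)[C@@H]1O` is 2,3,6-trifluorophenyl in place of 3-bromophenyl on a saturated chain carbon bound to a nitrogen on an aromatic ring. Within the data shown here, no measured step bears on this change in a readable way, since the only one recorded is unreadable and both compounds that have a number in this assay sit at the same limit. The expectation for compound 4 therefore rests on the two limits alone, and the step from compound 2 to compound 4 is expected to be a step that the limit leaves unreadable from compound 2 to compound 4, most likely leaving compound 4 at a limit as well. Compound 4 is estimated at 200000 nM, with a range from 40000 nM to 600000 nM in this assay.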

Compound 4, half-maximal inhibitory concentration: > 166000 nM
Compound 4: a limit, no number; the forecaster's own chance of this, stated with the estimate: 75%; the middle value lies beyond the limit too.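

Compound 4, like compound 1 and compound 2, gives only a limit in this assay, so neither step to compound 4 can be read: the limit of > 166000 nM in this assay, at which 3 of the 4 values shown sit.

The compounds shown leave open how these substituted phenyl groups rank against one another in this assay, with no single number among them.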